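A few compounds are considered here, and "the series" means these few. Any claim that something is new, unique, unknown or untested is made for them only; others in the source may bear on it.

Measured in an assay on isolated protein for inhibition of Ectonucleotide pyrophosphatase/phosphodiesterase family member 1 (Homo sapiens), using Lineweaver-Burk analysis; on this read-out higher numbers stand for weaker inhibition and lower numbers for stronger inhibition:
compound 1 `COc1ccc(NC(=O)CSc2nc3c(OC(C)C)nc(N)nc3[nH]2)cc1OC`: 11000 nM
compound 2 `COc1ccc(NC(=O)CSc2nc3c(N)nc(SC)nc3[nH]2)cc1OC`: 152 nM
compound 3 `COc1ccc(NC(=O)CSc2nc3nccnc3[nH]2)cc1OC`: 131 nM

Compound 2 has the second highest number of the three; compound 3 sits within the scatter of it, while compound 1 lies far higher, beyond the scatter. Compound 4 `COc1ccc(NC(=O)CSc2nc3c(N)ncnc3[nH]2)cc1OC` differs from compound 2 by hydrogen in place of methylsulfanyl on an aromatic carbon. Within the data shown here, no pair of measured compounds isolates this change. Compound 3, which carries neither the methylsulfanyl nor the amino group on that ring, gives 131 nM, close to compound 2, so the ring substituents do not appear decisive here. For compound 4 a step of a 1.5-fold higher number from compound 2 to compound 4 (0.18 log units; within the scatter) in this assay is expected, at most a slight weakening, likely within the scatter. Compound 4 is estimated at 230 nM, range 80 nM to 700 nM.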

Compound 4, inhibition constant: 5 nM
Beside the measured number, compound 4's estimate is 46-fold (1.66 log units) above it, and the stated range ends above it.
By their numbers in this assay, from the lowest: compound 4; then compounds 3 and 2 (each within the scatter of the next); then compound 1.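

In this assay, among these compounds, hydrogen in place of methylsulfanyl on the aromatic carbon between two ring nitrogen atoms gives a 30-fold lower number from compound 2 to compound 4 (1.48 log units; beyond the scatter) and so isolates this position for the first time. The position is therefore sensitive to substitution, with hydrogen giving much stronger inhibition than methylsulfanyl in this pair. No supporting data bear on the reason for this gain.

Still open, going by these compounds, is whether methyl, chlorine or an amine at this carbon would read closer to hydrogen or to methylsulfanyl. On these data alone, it is also open whether the gain persists without the amino group on the same ring.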